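Swapping an Aryl Ether for a Heteroaryl Amide

The source may hold more compounds than are shown below. What is called first, only, known or untested is meant among the compounds shown, and "the series" means these compounds.

Measured in an assay for inhibition of inositol hexakisphosphate kinase 2 (Homo sapiens), read by colorimetric assay, coupled enzyme assay and malachite green, with a stated time of 120 min, in the presence of a further agent that is not named here; on this read-out higher numbers stand for weaker inhibition and lower numbers for stronger inhibition:
compound 1 `O=C(O)/C=C/c1ccc2noc(-c3ccc(Oc4ccccc4)cc3)c2c1` gives 94 nM
compound 2 `O=C(O)c1ccc2noc(-c3ccc(Oc4ncc(Cl)cc4Cl)cc3)c2c1` gives 650 nM

Compound 2 carries the higher of the two numbers, and the gap to compound 1 lies beyond the usual scatter. Compound 3 `O=C(O)c1ccc2noc(-c3ccc(NC(=O)c4ccncn4)cc3)c2c1` differs from compound 2 in one place: ((pyrimidin-4-yl)carbonyl)amino in place of (3,5-dichloropyridin-2-yl)oxy on an aromatic carbon. Going by the values given here, no measured pair shows this exchange, so its effect cannot be read from the two compounds already in hand. The change is expected to move the number by no more than the scatter, in either direction, as the step of a 1.2-fold higher number from compound 2 to compound 3 (0.09 log units; within the scatter) expresses. Compound 3 is therefore estimated at 800 nM, within a range from 150 nM to 4000 nM.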

Compound 3, half-maximal inhibitory concentration: 720 nM
Compound 3: the middle estimate sits 1.1-fold (0.05 log units) above what was measured; the range from low to high includes it.
By their numbers in this assay, from the lowest: compound 1; then compounds 2 and 3 (each within the scatter of the next).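

At this place, on an aromatic carbon para to a large group, ((pyrimidin-4-yl)carbonyl)amino can stand in for (3,5-dichloropyridin-2-yl)oxy in this assay with a 1.1-fold higher number from compound 2 to compound 3 (0.04 log units; within the scatter) and no difference beyond the scatter. The two chlorine atoms and the ether oxygen can therefore be exchanged for an amide link and a pyrimidine ring without a readable difference in this assay. Nothing measured here accounts for this likeness. On these data alone, whether the amide link or the pyrimidine ring matters more stays open. A benzoylamino group or a plain amine at this place could separate the two.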